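A Trifluoromethyl Step from Compound 2 to Compound 3

A few compounds are considered here, and "the series" means these few. Any claim that something is new, unique, unknown or untested is made for them only; others in the source may bear on it.

Measured so far in an ADME assay on MDCK cells (Canis lupus familiaris) for cytotoxicity; on this read-out lower numbers stand for higher toxicity in this test and higher numbers for lower toxicity in this test:
- compound 1 `O=[N+]([O-])C1=CNc2nc(C(F)(F)F)nn2C1c1ccc(O)c(O)c1` gives 1210000 nM
- compound 2 `O=[N+]([O-])C1=CNc2ncnn2C1O` gives 123000 nM

Compound 2 has the lower of these two numbers, and its gap to compound 1 lies beyond the usual scatter. Compound 3 `O=[N+]([O-])C1=CNc2nc(C(F)(F)F)nn2C1O` has not yet been measured. It carries trifluoromethyl in place of hydrogen on an aromatic carbon. Going by the values given here, no measured step shows this change directly. Compound 1, which also bears trifluoromethyl, reads 1210000 nM, so a moderate rise in this assay is expected. The estimated step is a 2.8-fold higher number from compound 2 to compound 3 (0.45 log units; beyond the scatter). For compound 3 the expected value is 350000 nM, within an estimated range of 120000 nM to 1000000 nM.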

Compound 3, half-maximal cytotoxic concentration: 33000 nM
Compound 3: middle estimate off by 11-fold (1.03 log units), on the high side; measured number outside the range, below it.
By their numbers in this assay, from the lowest: compound 3; then compound 2; then compound 1.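

In this assay, trifluoromethyl in place of hydrogen on the aromatic carbon gives a 3.7-fold lower number from compound 2 to compound 3 (0.57 log units; beyond the scatter) and so shows that this position responds to the change, in the lower direction. Hydroxy in place of 3,4-dihydroxyphenyl on a saturated ring carbon gives a 37-fold lower number from compound 1 to compound 3 (1.56 log units; beyond the scatter) and is the larger step, so the high number of compound 1 goes with its 3,4-dihydroxyphenyl group and not with trifluoromethyl. No evidence here explains either step. Still open, from the compounds shown here alone, is whether a methyl group or chlorine on that aromatic carbon would also lower the number, and whether an amine in place of hydroxy would change it.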